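Chloro to trifluoromethoxy: what size of step to expect

The source may report more compounds than this note shows. Statements on the series, on what has been measured and on what is new or still open speak of the compounds shown alone.

Measured so far in a functional assay on LoVo cells (Homo sapiens) for inhibition, read by MTT assay, with a stated time of 72 h; a higher number here means a weaker inhibitor, a lower number a stronger inhibitor:
- Compound 1 `C=C(Br)C(=O)Nc1cccc(/C=C/C(=O)Nc2cccc(F)c2)c1`: 1000 nM
- Compound 2 `C=C(Br)C(=O)Nc1cccc(/C=C/C(=O)Nc2ccc(Cl)cc2)c1`: 5900 nM

Of these two, compound 2 has the higher number, which makes it the weaker inhibitor. Compound 3 `C=C(Br)C(=O)Nc1cccc(/C=C/C(=O)Nc2ccc(OC(F)(F)F)cc2)c1` has not yet been measured. It keeps the core of compound 2 and changes one group: trifluoromethoxy in place of chloro on an aromatic carbon. Trifluoromethoxy takes the place of chloro, para to a large group.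

Among the compounds with values here, only one measured step bears on this: a 5.9-fold higher number from compound 1 to compound 2 (0.77 log units; beyond the scatter). This modest step replaced 3-fluorophenyl with 4-chlorophenyl, so it shows that this end of the molecule can move the number. It says nothing about trifluoromethoxy, however. In this assay, no firm direction can therefore be expected, and the step may well stay within the scatter.

The expected change is a 1.2-fold lower number from compound 2 to compound 3 (0.07 log units; within the scatter). For compound 3, the estimated value is 5000 nM, with an expected range of 1700 nM to 14000 nM.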

Compound 3, half-maximal inhibitory concentration: 30300 nM
Compound 3: middle estimate off by 6.1-fold (0.78 log units), on the low side; the measured number lies above the stated range.
By their numbers in this assay, from the lowest: compound 1; then compound 2; then compound 3.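

Measured in this assay the swap of chloro for trifluoromethoxy, on an aromatic carbon para to a large group, gives a 5.1-fold higher number from compound 2 to compound 3 (0.71 log units; beyond the scatter) and so makes a clear difference rather than a neutral exchange. The earlier step replaced 3-fluorophenyl with 4-chlorophenyl, changing the group and its place together, whereas this step keeps the place fixed and changes only the group, which shows that the group on this carbon can shift the number by itself. Nothing measured here explains the rise.

Still open, as far as these compounds go, is how other groups on this same carbon would behave, such as a methyl, a methoxy, an amine or a carboxylic acid. Also open, from the compounds shown here alone, is whether trifluoromethoxy would give a similar step at another place on this ring.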